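Isobutyl for Cyclopentyl on a Sulfonamide Nitrogen

This account rests on a few compounds, and the source may have more. Where it says the series, first, only, none or still open, it means among the compounds named here.

Compound 1, `CC[C@@H]1C(=O)N(C)c2cnc(Nc3ccc(S(=O)(=O)NC4CCCC4)cc3)nc2N1C1CCCC1`, gives 688 nM.
Compound 2, `CCC1C(=O)N(C)c2cnc(-n3ccc4cc(C(=O)NC)ccc43)nc2N1c1ccn(C)n1`, gives 35400 nM.
Compound 3, `CCC1C(=O)N(C)c2cnc(-n3ccc4cc(C(=O)NC(C)C)ccc43)nc2N1c1ccn(C)n1`, gives 8420 nM.

These three compounds were tested in a functional assay on MCF7 cells (Homo sapiens) for antiproliferative activity, read by CCK-8 assay, with a stated time of 72 h; on this read-out higher numbers stand for weaker inhibition of growth and lower numbers for stronger inhibition of growth. On those numbers compound 1 stands lowest of the three: compound 3 lies a long way above it, and compound 2 further still. Among the measured compounds shown here, compound 2 and compound 3 share a core that differs from that of compound 1, and the only single-place step among them, a 4.2-fold lower number from compound 2 to compound 3 (0.62 log units; beyond the scatter), concerns a group on an amide-type nitrogen rather than a sulfonamide.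

The unmeasured compound 4, `CC[C@@H]1C(=O)N(C)c2cnc(Nc3ccc(S(=O)(=O)NCC(C)C)cc3)nc2N1C1CCCC1`, is compound 1 with one change: isobutyl in place of cyclopentyl on a sulfonamide nitrogen. For the measured compounds named here, no measured step touches a sulfonamide nitrogen, and the one step in hand sits on a different core and a different kind of nitrogen, so it bears on this change only loosely. That step was modest, and the change here swaps one group for another of nearly the same size with no ring and no change in donors or acceptors, so no step beyond the scatter is expected in this assay. Compound 4 is therefore estimated at 800 nM, within 300 nM to 2500 nM, a step of a 1.2-fold higher number from compound 1 to compound 4 (0.07 log units; within the scatter) that is expected to stay inside the usual scatter.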

Compound 4, concentration for 50% growth inhibition: 403 nM
Compound 4: the middle estimate sits 2.0-fold (0.30 log units) above what was measured; the measured number falls inside the stated range.
By their numbers in this assay, from the lowest: compounds 4 and 1 (each within the scatter of the next); then compound 3; then compound 2.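

In this assay, among the compounds shown here, the step of a 1.7-fold lower number from compound 1 to compound 4 (0.23 log units; within the scatter) gives the first reading at the sulfonamide nitrogen, and it lies within the scatter, so the cyclopentyl and isobutyl compounds cannot be told apart in this assay. For the compounds shown here, on the core of compound 1, then, a five-membered carbon ring on this nitrogen can give way to an open isobutyl chain, with one heavy atom fewer, without a change that the read-out can resolve, whereas the only earlier single-place step concerned an amide-type nitrogen on a different core and lay beyond the scatter. No measurement is available that would account for this result.

The two groups shown on this nitrogen are both built of carbon alone, so the compounds leave open how the number would respond to an amine, a carboxylic acid, a hydroxyl group or a longer chain there. They also leave open whether the same exchange would read the same way on another core, as neither compound 2 nor compound 3 carries a sulfonamide.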